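Swapping the pyridyl ether head for a trifluoromethylphenyl ether

A few compounds are considered here, and "the series" means these few. Any claim that something is new, unique, unknown or untested is made for them only; others in the source may bear on it.

Measured so far:
- compound 1, `COc1cccc(OC(c2ccc(C(F)(F)F)cc2)C2CCN(C(C)CCNC(=O)c3c(Cl)cncc3Cl)CC2)n1`: 32700 nM
- compound 2, `CC(CCNC(=O)c1c(Cl)cncc1Cl)N1CCC(C(Oc2cc(Cl)ccn2)c2ccc(C(F)(F)F)cc2)CC1`: 4260 nM

In an ADME assay on PBMC cells (Homo sapiens) for cytotoxicity (a higher number here means that more compound is tolerated, a lower number that less compound is tolerated), compound 2 stands lowest of the two numbers; its nearest neighbour, compound 1, lies a modest step higher, a 7.7-fold lower number from compound 1 to compound 2 (0.89 log units; beyond the scatter), which came from exchanging the group on the oxygen on a saturated carbon. Compound 3, `CC(CCNC(=O)c1c(Cl)cncc1Cl)N1CCC(C(Oc2ccccc2C(F)(F)F)c2ccc(C(F)(F)F)cc2)CC1`, changes that same group again: 2-(trifluoromethyl)phenyl in place of 4-chloropyridin-2-yl on an oxygen on a saturated carbon. Within the data shown here, the one measured step shows this position can shift the number beyond the scatter, but it gives no direction for a carbon-only ring bearing a trifluoromethyl group. A modest move either way is therefore plausible, so compound 3 is estimated at 6000 nM, between 1500 nM and 25000 nM, an expected step of a 1.4-fold higher number from compound 2 to compound 3 (0.15 log units; within the scatter).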

Compound 3, half-maximal cytotoxic concentration: 12500 nM
Beside the measured number, compound 3's estimate is 2.1-fold (0.32 log units) below it; the measured number falls inside the stated range.
By their numbers in this assay, from the lowest: compound 2; then compound 3; then compound 1.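

In this assay the carbon-only 2-(trifluoromethyl)phenyl gives a 2.9-fold higher number from compound 2 to compound 3 (0.47 log units; beyond the scatter) and also a 2.6-fold lower number from compound 1 to compound 3 (0.42 log units; beyond the scatter). A ring without a ring nitrogen therefore lands in the middle of the three, so having a pyridine on this oxygen does not by itself set the number. No measurement here accounts for this order. Still open, going by these compounds, is how a plain phenyl would compare at this oxygen, and whether a phenyl ring carrying a nitrile or a carboxylic acid would move the number further.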